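Ethyl to Isopropyl on a Shared Aminoimidazoline Core

This account rests on a few compounds, and the source may have more. Where it says the series, first, only, none or still open, it means among the compounds named here.

Compound 2 `CCn1ncnc1-c1ccccc1NCC1=NCCN1` and compound 1 `Cc1nc(-c2ccccc2NCC2=NCCN2)n(C)n1` share a core, and in a functional assay with Alpha-1A adrenergic receptor (Homo sapiens) as the target, read by calcium flux (a lower number here means a smaller maximal response, a higher number a larger maximal response), compound 2 gives 107% while compound 1 gives 98%, two values that lie within the usual scatter of each other. Compound 3 `CC(C)n1ncnc1-c1ccccc1NCC1=NCCN1` differs from compound 2 in one place: methyl in place of hydrogen on a saturated chain carbon bound to an aromatic nitrogen and a saturated chain carbon. No measured step of this kind exists among these compounds, so the step from compound 2 to compound 3 is expected to stay within the scatter, in no clear direction. For compound 3 the maximal response in this assay is estimated at 105%, with a range from 90% to 120%. The expected step is a number 2 percentage points lower from compound 2 to compound 3 (within the scatter).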

Compound 3, largest response reached (reported as maximal response), in percent of the reference or control that the assay uses: 104%
The estimate for compound 3 lay 1 percentage points above the measured number, and the stated range covers the measured number.
By their numbers in this assay, from the lowest: compounds 1, 3 and 2 (each within the scatter of the next).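

In this assay the change from ethyl to isopropyl gives a number 3 percentage points lower from compound 2 to compound 3 (within the scatter) and is the only measured step at this position among these compounds. Adding a methyl on this saturated chain carbon therefore leaves the maximal response within the scatter, so this position accepts the larger isopropyl group without a clear change in this read-out. Nothing measured here offers an explanation for this result.

Going by these compounds, whether a longer chain such as n-butyl, or a chain carrying an amine or a carboxylic acid, would also leave the response within the scatter remains open.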